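A few compounds are considered here, and "the series" means these few. Any claim that something is new, unique, unknown or untested is made for them only; others in the source may bear on it.

In a functional assay on MCF7 cells (Homo sapiens) for cytotoxicity, read by MTT assay, with a stated time of 48 h (on this read-out lower numbers stand for stronger inhibition and higher numbers for weaker inhibition), two compounds sharing one core have been measured so far. Compound 1 `Cc1ccccc1-c1nnc(SCCn2c([N+](=O)[O-])cnc2C)o1` gives 15800 nM, and compound 2 `Cc1ncc([N+](=O)[O-])n1CCSc1nnc(-c2ccco2)o1` gives 29500 nM. These two numbers lie within the usual scatter of each other, so compound 2 cannot be told apart from compound 1 on this read-out. Still unmeasured, compound 3 `Cc1ncc([N+](=O)[O-])n1CCSc1nnc(-c2cccnc2)o1` keeps the core of compound 2 and differs in one group: pyridin-3-yl in place of furan-2-yl on an aromatic carbon. Here pyridin-3-yl stands in place of furan-2-yl on an aromatic carbon of a five-membered aromatic ring with 2 nitrogen and 1 oxygen. Among the compounds with values here, only one measured step bears on this change: a 1.9-fold higher number from compound 1 to compound 2 (0.27 log units; within the scatter), with furan-2-yl in place of 2-methylphenyl, and it stays within the scatter. A single step is thin evidence, but it gives no reason to expect a larger move, so a change beyond the scatter is not expected in this assay, and neither direction is clearly favoured. The expected step is a 1.3-fold lower number from compound 2 to compound 3 (0.11 log units; within the scatter). For compound 3 the estimated value is 23000 nM, with an expected range from 9000 nM to 60000 nM.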

Compound 3, half-maximal inhibitory concentration: 28700 nM
Estimate against measurement, compound 3: 1.2-fold (0.10 log units) below; low and high end bracket the measured number.
By their numbers in this assay, from the lowest: compounds 1, 3 and 2 (each within the scatter of the next).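

In this assay, this carbon of the shared core, next to the ring nitrogen and the ring oxygen, has now carried three different aromatic rings, and the new result is a 1.0-fold lower number from compound 2 to compound 3 (0.01 log units; within the scatter). A six-membered ring with one nitrogen therefore stands in for a five-membered ring with one oxygen without a difference that this read-out can resolve, and the comparison with the 2-methylphenyl group, a 1.8-fold higher number from compound 1 to compound 3 (0.26 log units; within the scatter), gives the same picture, so compound 1, compound 2 and compound 3 cannot be told apart here. This holds only for these three compounds, and no measurement at hand explains why the three groups read alike.

Going by these compounds, all three groups are aromatic rings with no net charge, so it remains open whether an amine, a carboxylic acid or a longer alkyl chain on this carbon would give a step beyond the scatter. Also open, on these data alone, is whether moving the ring nitrogen, as in pyridin-2-yl or pyridin-4-yl, would change the number at all.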